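The source may hold more compounds than are shown below. What is called first, only, known or untested is meant among the compounds shown, and "the series" means these compounds.

Compound 2, `COc1cc2cc(Oc3ccc(NC(=O)Nc4ccc(Cl)c(C(F)(F)F)c4)cc3)c(C)nc2cc1OC`, stands at the lower of the two numbers gathered so far in a functional assay on U-251 cells (Homo sapiens) for inhibition, read by sulforhodamine B assay, with a stated time of 48 h; on this read-out lower numbers stand for stronger inhibition of growth and higher numbers for weaker inhibition of growth. In this assay compound 2 gives 1030 nM. Its nearest neighbour is compound 1, `COc1cc2cc(Oc3ccc(NC(=O)Nc4cccc(C(F)(F)F)c4)cc3)c(C)nc2cc1OC`, which in this assay gives 1560 nM; the step of a 1.5-fold lower number from compound 1 to compound 2 (0.18 log units; within the scatter) separates the two, and that step is within the scatter, so the two compounds cannot be told apart on these numbers.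

Compound 3, `COc1cc2cc(Oc3ccc(NC(=O)Nc4ccc(Cl)c(Cl)c4)cc3)c(C)nc2cc1OC`, has not been measured yet. It differs from compound 2 by chloro in place of trifluoromethyl on an aromatic carbon. Within the data shown here, no measured step involves this exchange: the only step known, from compound 1 to compound 2, concerns a different place and was within the scatter. Nothing on hand therefore points to a change of size beyond the scatter in either direction in this assay, and the expectation for compound 3 rests on that absence alone. On this basis the step of a 1.3-fold higher number from compound 2 to compound 3 (0.10 log units; within the scatter) is expected to stay within the scatter. Compound 3 is accordingly estimated at 1300 nM, with a range from 500 nM to 3500 nM.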

Compound 3, concentration for 50% growth inhibition: 2190 nM
Beside the measured number, compound 3's estimate is 1.7-fold (0.23 log units) below it, within the range that was stated.
By their numbers in this assay, from the lowest: compounds 2, 1 and 3 (each within the scatter of the next, the first and the last beyond it).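

Among these compounds, exchanging trifluoromethyl for chloro on this aromatic carbon, ortho to a chloro group and meta to a large group, is the first change in this assay to pass beyond the scatter: it gives a 2.1-fold higher number from compound 2 to compound 3 (0.33 log units; beyond the scatter), a modest step that shows this position is not indifferent to what it carries, at least while the neighbouring chloro group is present. Among the compounds shown here, the comparison with the compound lacking that chloro group does not separate the two, since 3,4-dichlorophenyl in place of 3-(trifluoromethyl)phenyl gives a 1.4-fold higher number from compound 1 to compound 3 (0.15 log units; within the scatter), so of the three compounds only the pair of compound 2 and compound 3 can be told apart. Nothing on hand offers an explanation for the step between that pair.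

The compounds shown leave open whether a methyl, a nitrile or an amine on this same aromatic carbon would fall with trifluoromethyl or with chloro in this assay. They also leave open whether the exchange of trifluoromethyl for chloro would give a step of similar size with hydrogen in place of the neighbouring chloro group.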